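The source may hold more compounds than are shown below. What is called first, only, known or untested is meant among the compounds shown, and "the series" means these compounds.

Compound 1 `CCN(CC)C(=O)CN(c1cc(Cl)ccc1OC)S(=O)(=O)c1ccccc1` gives > 20000 nM in a functional assay on SH-SY5Y cells (Homo sapiens), read by MTT assay, with a stated time of 24 h (on this read-out higher numbers stand for an effect only at larger amounts of compound and lower numbers for an effect already at smaller amounts), a limit of the assay. Compound 2 `COc1ccc(CNC(=O)CN(c2cc(Cl)ccc2OC)S(=O)(=O)c2ccccc2)cc1` gives > 20000 nM, likewise a limit. Compound 3 `COc1ccc(Cl)cc1N(CC(=O)Nc1ccc(Cl)cc1)S(=O)(=O)c1ccccc1` gives > 20000 nM, again a limit.

Compound 3 thus stands at the limit of > 20000 nM in this assay, at which 3 of the 3 values shown sit, and no order among the three measured compounds can be read. The change to compound 4 `COc1ccc(Cl)cc1NC(=O)CN(c1cc(Cl)ccc1OC)S(=O)(=O)c1ccccc1` is 5-chloro-2-methoxyphenyl in place of 4-chlorophenyl on an amide-type nitrogen. The measured steps that bear on this position, a step that the two limits leave unreadable from compound 1 to compound 3, a step that the two limits leave unreadable from compound 2 to compound 3 and a step that the two limits leave unreadable from compound 1 to compound 2, all run between limits and give no readable size, so no step beyond the scatter can be foreseen in either direction in this assay. Compound 4 is expected to remain at the limit as well, with an estimate of 30000 nM and a range from 15000 nM to 100000 nM. The step this estimate implies, a step that the limit leaves unreadable from compound 3 to compound 4, is expected to be unreadable in the same way.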

Compound 4, half-maximal effective concentration: > 20000 nM
Compound 4: a limit, no number; the forecaster's own chance of this, stated with the estimate: 85%; the middle value lies beyond the limit too.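

Within the data shown here, no step among compound 1, compound 2, compound 3 and compound 4 can be read, since all four stand at a limit: the limit of > 20000 nM in this assay, at which 4 of the 4 values shown sit. The compounds shown leave open whether any change on the amide-type nitrogen alters the effect.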